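This account rests on a few compounds, and the source may have more. Where it says the series, first, only, none or still open, it means among the compounds named here.

Of the compounds shown here, three from this series have been tested in a functional assay on the whole organism (Tail, strain ICR) with Mus musculus as the target, in the tail flick test, with a stated time of 60 min, at a dose of 25 umol/kg by the oral route; a lower number here means a weaker effect, a higher number a stronger effect of the compound at the dose given. Compound 1, `O=C(CN(c1ncnc2c1ncn2C1CCCCO1)C1CC1)N[C@@H](CO)C(=O)OCc1ccccc1`, gives 46.7% in this assay. Compound 2, `CSCC[C@H](NC(=O)CN(c1nc(Cl)nc2[nH]cnc12)C1CC1)C(=O)OCc1ccccc1`, gives 30.8%, and compound 3, `O=C(OCc1ccccc1)[C@@H]1CCCN1C(=O)CN(c1nc(Cl)nc2[nH]cnc12)C1CC1`, gives 34.4%. Compound 2 sits at the low end of these three numbers: its gap to compound 3 is within the usual scatter of repeated measurements, so the two cannot be told apart, while compound 1 lies higher by more than the scatter.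

Compound 4, `CC(C)[C@H](NC(=O)CN(c1nc(Cl)nc2[nH]cnc12)C1CC1)C(=O)OCc1ccccc1`, has not yet been measured. It differs from compound 2 in one place: isopropyl in place of 2-(methylsulfanyl)ethyl on a saturated chain carbon bound to an amide-type nitrogen and a carbonyl carbon. The shared core and the rest of the chain are unchanged.

Going by the values given here, no step between two measured compounds mirrors this change, so there is nothing to lean on beyond the values themselves. The step from compound 2 to compound 4 in this assay is expected to be small, a number 4.2 percentage points higher from compound 2 to compound 4 (within the scatter), in either direction and most likely not beyond the scatter. Compound 4 is therefore estimated at 35%, with a range from 22% to 50%.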

Compound 4, a percentage reported as activity, at one dose (the size of the read-out at that dose, not a potency): 55.5%
For compound 4 the middle estimate is 20.5 percentage points below the measured one; measured number above the stated range.
By their numbers in this assay, from the lowest: compounds 2 and 3 (each within the scatter of the next); then compounds 1 and 4 (each within the scatter of the next).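

In this assay, putting isopropyl in place of 2-(methylsulfanyl)ethyl on a saturated chain carbon bound to an amide-type nitrogen and a carbonyl carbon goes with a number 24.7 percentage points higher from compound 2 to compound 4 (beyond the scatter). Going by these compounds alone, this is the first change in one place, and it shows that the read-out responds to the group at this position while the shared core and the rest of the chain stay the same. The entering group has one heavy atom fewer, no sulfur and no hydrogen-bond acceptor, and a single step cannot separate these differences.

From the compounds shown here alone, whether an amine, a carboxylic acid or a longer chain at this position would raise the number further or lower it remains open. Nothing measured here gives a reason for the step.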